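Methoxymethyl in Place of Thiazolyl on a Stable Core

A few compounds are considered here, and "the series" means these few. Any claim that something is new, unique, unknown or untested is made for them only; others in the source may bear on it.

compound 1, `O=c1n(Cc2nc(-c3nccs3)cn2CCCCO)c2cnccc2n1C1CC1`: < 8 mL.min-1.g-1
compound 2, `COC(=O)N1CCC(n2ccc(Cc3nc4ccccc4n3CCCCO)n2)CC1`: 110 mL.min-1.g-1
compound 3, `CC(C)n1nc(Cn2c(=O)c3ccccc3n2CCCCO)c2ccccc21`: 462 mL.min-1.g-1

In an ADME assay on microsomes from liver (Homo sapiens) for metabolic stability (on this read-out higher numbers stand for fast clearance and lower numbers for slow clearance), compound 1 gives < 8 mL.min-1.g-1, which is a limit of the assay and not a number. Compound 1 therefore stands at the limit of < 8 mL.min-1.g-1 in this assay, at which 1 of the 3 values shown sits, while compound 2 and compound 3 each give a numeric value in this assay.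

Compound 4, `COCc1cn(CCCCO)c(Cn2c(=O)n(C3CC3)c3ccncc32)n1`, has not yet been measured. It differs from compound 1 by methoxymethyl in place of 1,3-thiazol-2-yl on an aromatic carbon. Among the compounds with values here, no measured pair shows this change, so its size cannot be read from the data; a small rise in clearance, close to the edge of the usual scatter, is expected. Compound 4 is expected at 15 mL.min-1.g-1, in the range 5 mL.min-1.g-1 to 45 mL.min-1.g-1. The expected step is an at least 1.8-fold higher number from compound 1 to compound 4 (0.27 log units; that floor lies within the scatter).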

Compound 4, intrinsic clearance in microsomes: 9 mL.min-1.g-1
Compound 4: the middle estimate sits 1.7-fold (0.22 log units) above what was measured, and the stated range covers the measured number.
By their numbers in this assay, from the lowest: compound 4; then compound 2; then compound 3. At a limit, below all of these: compound 1.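

In this assay, this position on the aromatic carbon takes methoxymethyl in place of 1,3-thiazol-2-yl, a ring swapped for a group with no ring, and the change reads as an at least 1.1-fold higher number from compound 1 to compound 4 (0.05 log units; that floor lies within the scatter). On the core of compound 1, then, clearance does not need the 1,3-thiazol-2-yl ring to stay in this range, with compound 4 at 9 mL.min-1.g-1. The number for compound 1 is a limit of the assay, so the step can be read only as a floor: the limit of < 8 mL.min-1.g-1 in this assay, at which 1 of the 4 values shown sits.

As far as these compounds go, how an amine or a longer ether chain at this position would read in this assay stays open.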